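This account rests on a few compounds, and the source may have more. Where it says the series, first, only, none or still open, it means among the compounds named here.

In a functional assay on U-937 cells (Homo sapiens) for antiproliferative activity, read by CCK-8 assay, with a stated time of 24 h (a higher number here means a weaker inhibitor, a lower number a stronger inhibitor), compound 1 `CC1CCN(Cc2ccc3nc(NC(=O)N/N=C/c4ccccn4)sc3c2)CC1` gives 21500 nM. Compound 2 `CN(C)Cc1ccc(NC(=O)N/N=C/c2ccccn2)cc1` reads > 40000 nM, which is a limit of the assay and not a number. Compound 3 `CC1CCN(Cc2ccc(NC(=O)N/N=C/c3ccccn3)cc2)CC1` differs from compound 2 by 4-methylpiperidin-1-yl in place of dimethylamino on a saturated chain carbon bound to an aromatic carbon, with 4-methylpiperidin-1-yl in place of dimethylamino on a saturated chain carbon bound to an aromatic carbon. Compound 1 also carries 4-methylpiperidin-1-yl, on a different core, and gives 21500 nM. On that single reading, a modest move towards a lower number is expected in this assay, with an estimated at least 1.6-fold lower number from compound 2 to compound 3 (0.20 log units; that floor lies within the scatter). For compound 3, the expected half-maximal inhibitory concentration is 25000 nM, with an estimated range of 10000 nM to 50000 nM.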

Compound 3, half-maximal inhibitory concentration: > 40000 nM
Compound 3 was reported as a limit; the forecaster's own chance of this, stated with the estimate: 35%; middle value at least 1.6-fold (0.20 log units) from the limit.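

No step from compound 2 to compound 3 can be read in this assay, because both stand at a limit of the assay, not at a number: the limit of > 40000 nM in this assay, at which 2 of the 3 values shown sit.

From the compounds shown here alone, whether 4-methylpiperidin-1-yl in place of dimethylamino changes the half-maximal inhibitory concentration at all on this core stays open.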